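The source may hold more compounds than are shown below. What is called first, only, known or untested is meant among the compounds shown, and "the series" means these compounds.

Measured compounds:
compound 1 `CC(C#Cc1cccc(C(=O)NCCC(c2ccccc2)c2ccc(F)cc2)c1)N(O)C(N)=O` — 160 nM
compound 2 `CC(C#Cc1cccc(C(=O)NCCC(c2ccccc2)c2ccc(C(F)(F)F)cc2)c1)N(O)C(N)=O` — 150 nM

In an assay for inhibition of Polyunsaturated fatty acid 5-lipoxygenase (Homo sapiens), read by HPLC, with stated times of 15 min and 10 min (a lower number here means a stronger inhibitor, a higher number a weaker inhibitor), compound 1 gives 160 nM and compound 2 gives 150 nM; the change from compound 1 to compound 2, trifluoromethyl in place of fluoro on an aromatic carbon, moves the number by a 1.1-fold lower number from compound 1 to compound 2 (0.03 log units; within the scatter), so neither compound stands apart from the other in this assay.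

Compound 3 `CC(C#Cc1cccc(C(=O)NCCC(c2ccccc2)c2ccccc2)c1)N(O)C(N)=O` carries the change (hydrogen in place of trifluoromethyl on an aromatic carbon), hydrogen in place of trifluoromethyl on an aromatic carbon of a six-membered aromatic ring of carbon only. For the measured compounds named here, the only step that bears on it is the one from compound 1 to compound 2, which exchanged two different groups at this same carbon and stayed within the scatter at a 1.1-fold lower number from compound 1 to compound 2 (0.03 log units; within the scatter). Compound 3 is therefore expected to show a step of a 1.1-fold higher number from compound 2 to compound 3 (0.05 log units; within the scatter) in this assay, none beyond the scatter. The estimate for compound 3 is 170 nM, within a range of 80 nM to 360 nM.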

Compound 3, half-maximal inhibitory concentration: 300 nM
Estimate against measurement, compound 3: 1.8-fold (0.25 log units) below, and the stated range covers the measured number.
By their numbers in this assay, from the lowest: compounds 2, 1 and 3 (each within the scatter of the next).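

In this assay, for the compounds shown here, hydrogen in place of trifluoromethyl gives a 2.0-fold higher number from compound 2 to compound 3 (0.30 log units; within the scatter) and hydrogen in place of fluoro gives a 1.9-fold higher number from compound 1 to compound 3 (0.27 log units; within the scatter) so the comparison at this place now includes the plain phenyl and not only two substituted rings. Both steps are larger than the earlier one, yet neither leaves the scatter, so fluoro, trifluoromethyl and hydrogen cannot be told apart here, and the data show no need for a substituent at this carbon for inhibition at this level. Nothing further is available to explain these numbers.

From the compounds shown here alone, whether an amine, a carboxylic acid or a methoxy group at this place would stay within the same range remains open. Also open is whether the same match among these three would hold on a core other than the shared one.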